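A Biphenyl Replacement Weighed Against Cell Tolerance

This account rests on a few compounds, and the source may have more. Where it says the series, first, only, none or still open, it means among the compounds named here.

Among the measured compounds shown here, in an ADME assay on A549 cells (Homo sapiens) for cytotoxicity, read by CellTiter-Glo (a lower number here means that less compound is tolerated, a higher number that more compound is tolerated), compound 3 `Cc1c(Cc2ccc(F)cc2Cl)c(=O)oc2cc(OCC(O)CN3CCC(C(N)=O)CC3)ccc12` gives 90800 nM, the only actual number in this small set. Compound 1 `Cc1ccc2nc(NCC(O)COc3ccc4c(C)c(Cc5ccccc5)c(=O)oc4c3)sc2c1` reaches only a limit, > 100000 nM. Compound 2 `Cc1cc(=O)oc2cc(OCC(O)CN3CCC(C(N)=O)CC3)ccc12` likewise reaches only a limit, > 100000 nM. The set is thus dominated by the limit of > 100000 nM in this assay, at which 2 of the 3 values shown sit. For the measured compounds named here, the one recorded step, an at least 1.1-fold lower number from compound 2 to compound 3 (0.04 log units; that floor lies within the scatter), stays within the scatter. Compound 4 `Cc1c(Cc2ccc(-c3ccccc3)cc2)c(=O)oc2cc(OCC(O)CN3CCC(C(N)=O)CC3)ccc12` differs from compound 3 by 4-phenylphenyl in place of 2-chloro-4-fluorophenyl on a saturated chain carbon bound to an aromatic carbon. Going by the values given here, no measured step swaps one aryl group for another, and the single available step did not move the read-out beyond the scatter, so no shift beyond it is expected in this assay, with a result at the assay ceiling remaining plausible. Compound 4 is therefore estimated at 65000 nM, between 20000 nM and 100000 nM, an expected step of a 1.4-fold lower number from compound 3 to compound 4 (0.15 log units; within the scatter) within the scatter.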

Compound 4, half-maximal cytotoxic concentration: > 100000 nM
Compound 4: a limit, no number (the forecaster's own chance of this, stated with the estimate: 45%); middle value at least 1.5-fold (0.18 log units) away from the limit.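

On the saturated chain carbon bound to an aromatic carbon, 4-phenylphenyl in place of 2-chloro-4-fluorophenyl gives an at least 1.1-fold higher number from compound 3 to compound 4 (0.04 log units; that floor lies within the scatter) in this assay. Among the compounds shown here, this is the first aryl-for-aryl change in the set, and with two six-membered aromatic rings in place of one, the read-out shows no shift beyond the scatter. The value of compound 4 is a limit, and the compounds at that limit cannot be ranked against one another: the limit of > 100000 nM in this assay, at which 3 of the 4 values shown sit.

Going by these compounds, whether a benzyl group carrying an amine or a carboxylic acid would behave the same way at this position remains open.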